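This account rests on a few compounds, and the source may have more. Where it says the series, first, only, none or still open, it means among the compounds named here.

For the measured compounds named here, in a toxicity assay on CHO cells (Cricetulus griseus) for cytotoxicity, read by WST assay, with a stated time of 24 h (on this read-out higher numbers stand for weaker inhibition and lower numbers for stronger inhibition), compound 3 `CC(C)=CCC/C(C)=C\CCC(C)=CCNCCCCN` gives 18100 nM, the only actual number among the three values so far. Compound 1 `CC(C)=CCCC(C)=CCNCCCN1CCCC1` reads > 150000 nM, which is a limit of the assay. Compound 2 `CC(C)=CCCC(C)=CCNCCCN(C)CCCN` reads > 150000 nM, which is again a limit. Compound 3 thus stands apart from the limit of > 150000 nM in this assay, at which 2 of the 3 values shown sit. Compound 4 `CC(C)=CCC/C(C)=C\CCC(C)=CCNCCCNCCCN` differs from compound 3 by (3-aminopropyl)amino in place of aminomethyl on a saturated chain carbon, three bonds along the chain from an amine nitrogen. The nearest measured comparison is a step that the two limits leave unreadable from compound 1 to compound 2, and it offers no size to carry over. Going by the values given here, with no measured step to suggest a shift in either direction, the expected change is a 1.4-fold higher number from compound 3 to compound 4 (0.14 log units; within the scatter), and it is not expected to exceed the scatter. For compound 4 the estimated value in this assay is 25000 nM, within an expected range of 9000 nM to 70000 nM.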

Compound 4, half-maximal inhibitory concentration: 30200 nM
For compound 4 the middle estimate is 1.2-fold (0.08 log units) below the measured one; the range from low to high includes it.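

In this assay this position now gives a readable step, a 1.7-fold higher number from compound 3 to compound 4 (0.22 log units; within the scatter), whereas the earlier step between limits cannot be read. The change from aminomethyl to (3-aminopropyl)amino, with 5 heavy atoms entering for 2, thus leaves the number within the scatter on a saturated chain carbon, three bonds along the chain from an amine nitrogen. Neither compound 3 nor compound 4 sits at the limit held by the other compounds: the limit of > 150000 nM in this assay, at which 2 of the 4 values shown sit.

On these data alone, whether a carboxylic acid or a longer polyamine chain at this place would move the number beyond the scatter stays open.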